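Compound 3 against the 4-methylphenyl and hydroxy limit

The compounds below may be only part of what the source reports. "The series", "measured", "known", "first", "only" and "open" are said of these compounds alone.

- Compound 1 `Cc1ccc(C2=NN(c3ccc(S(C)(=O)=O)cc3)C(=O)CC2)cc1`: 17400 nM
- Compound 2 `Cc1cc(O)ccc1C1=NN(c2ccc(S(C)(=O)=O)cc2)C(=O)CC1`: > 100000 nM (a limit)

Both values come from a functional assay on SF-539 cells (Homo sapiens) for inhibition, read by sulforhodamine B assay, with a stated time of 48 h; on this read-out higher numbers stand for weaker inhibition of growth and lower numbers for stronger inhibition of growth. Compound 2 stands at the limit of > 100000 nM in this assay, at which 1 of the 2 values shown sits. That value is a limit of the assay and not a number.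

Compound 3 `CCc1ccc(C2=NN(c3ccc(S(C)(=O)=O)cc3)C(=O)CC2)cc1` has 4-ethylphenyl in place of 4-hydroxy-2-methylphenyl on a carbon with a double bond to nitrogen, next to the ring nitrogen: 4-ethylphenyl in place of 4-hydroxy-2-methylphenyl on a carbon with a double bond to nitrogen. Among the measured compounds shown here, only one measured step bears on this change: an at least 5.7-fold higher number from compound 1 to compound 2 (0.75 log units; beyond the scatter). It introduced the 4-hydroxy-2-methylphenyl group that now leaves. The 4-ethylphenyl of compound 3 is closer in structure to the 4-methylphenyl of compound 1 at 17400 nM, so a value near that one is expected. A step beyond the scatter is therefore expected in this assay, towards a lower number and stronger inhibition of growth. The expected step is an at least 5.8-fold lower number from compound 2 to compound 3 (0.76 log units; beyond the scatter). For compound 3 the estimated value is 17000 nM, with an expected range from 7000 nM to 45000 nM.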

Compound 3, concentration for total growth inhibition: 18900 nM
For compound 3 the middle estimate is 1.1-fold (0.05 log units) below the measured one, within the range that was stated.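

In this assay, the added methyl on the saturated chain carbon bound to an aromatic carbon gives a 1.1-fold higher number from compound 1 to compound 3 (0.04 log units; within the scatter), so the 4-methylphenyl and 4-ethylphenyl groups read alike at this position, and this position tolerates that small extension of the chain. Replacing the 4-hydroxy-2-methylphenyl group with 4-ethylphenyl gives an at least 5.2-fold lower number from compound 2 to compound 3 (0.72 log units; beyond the scatter), so a second group without the hydroxy also sits far from the compound 2 reading, and the weak result is no longer tied to a single comparison with compound 1. As far as these compounds go, compound 2 remains a limit and not a number, so the full size of this step stays unknown: the limit of > 100000 nM in this assay, at which 1 of the 3 values shown sits.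

The compounds shown do not separate the hydroxy from the added ring methyl within the 4-hydroxy-2-methylphenyl group, so either one or the pair together could account for the change. From the compounds shown here alone, how far the flat reading extends also stays open, since a longer chain such as propyl or butyl, or an amine or carboxylic acid in the same place on the phenyl ring, would test it further.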